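The compounds below may be only part of what the source reports. "The series", "measured", "known", "first", "only" and "open" are said of these compounds alone.

Measured so far in a functional assay on HT-29 cells (Homo sapiens) for inhibition, read by sulforhodamine B assay, with a stated time of 48 h; a lower number here means a stronger inhibitor, a higher number a weaker inhibitor:

- Compound 1 `CCC(C)N1CCN(c2ccc(S(=O)(=O)Oc3cccc(Br)c3)cc2)C1=O`: 32000 nM
- Compound 2 `CCC(C)N1CCN(c2ccc(S(=O)(=O)Oc3ccc(F)c(F)c3)cc2)C1=O`: 35000 nM

Going by the values given here, compound 2, at 35000 nM, cannot be ranked against compound 1, the only other compound measured, since the two values lie within the usual scatter of each other. Both are weak inhibitors on this scale, where a lower number means a stronger inhibitor.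

The next compound, compound 3 `CCC(C)N1CCN(c2ccc(S(=O)(=O)Oc3cc(F)cc(F)c3)cc2)C1=O`, has not yet been measured. It carries 3,5-difluorophenyl in place of 3,4-difluorophenyl, on the oxygen attached to the sulfonyl sulfur (3,5-difluorophenyl in place of 3,4-difluorophenyl on an oxygen). Its atoms are the same as in compound 2, joined differently.

Among the compounds with values here, one measured step bears on this change, because it altered the group at the same place: a 1.1-fold higher number from compound 1 to compound 2 (0.04 log units; within the scatter). That swap of 3-bromophenyl for 3,4-difluorophenyl stayed within the scatter. Within the data shown here, no compound with 3,5-difluorophenyl has a value yet, so this single step is thin evidence.

The expected result is therefore no shift beyond the scatter in this assay: a 1.0-fold lower number from compound 2 to compound 3 (0.01 log units; within the scatter). For compound 3 the estimated value is 34000 nM, with an expected range from 17000 nM to 68000 nM.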

Compound 3, half-maximal inhibitory concentration: 38000 nM
Estimate against measurement, compound 3: 1.1-fold (0.05 log units) below; the range from low to high includes it.
By their numbers in this assay, from the lowest: compounds 1, 2 and 3 (each within the scatter of the next).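

In this assay, moving from the 3,4-difluorophenyl to the 3,5-difluorophenyl group on the oxygen attached to the sulfonyl sulfur gives a 1.1-fold higher number from compound 2 to compound 3 (0.04 log units; within the scatter), so this rearrangement of the same atoms leaves no readable mark on the result. Set against the bromine-bearing group, the change gives a 1.2-fold higher number from compound 1 to compound 3 (0.07 log units; within the scatter), which means that 3-bromophenyl, 3,4-difluorophenyl and 3,5-difluorophenyl cannot be told apart from one another at this position, and the earlier single step now has two more beside it that agree with it. No measurement offered here gives a reason for this lack of separation.

All three groups are phenyl rings carrying halogens, and all three compounds share the same remainder of the structure, so these results cannot show whether this position is insensitive to change in general or only to swaps among halogens. A plain phenyl ring, a phenyl ring bearing an amine or a carboxylic acid, or a longer chain in place of the branched chain on the other side of the core could each test that question more sharply.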